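Branched Chain at the Ring Carbon: Compound 3 Expected

A few compounds are considered here, and "the series" means these few. Any claim that something is new, unique, unknown or untested is made for them only; others in the source may bear on it.

Compounds measured so far in an assay on Sf9 cells for inhibition of serine/threonine-protein kinase 4 (Homo sapiens), read by luminescence and ADP-Glo, with a stated time of 1 h, in the presence of a further agent that is not named here; a higher number here means a weaker inhibitor, a lower number a stronger inhibitor:
compound 1 `CN1C(=O)C(C2CC2)N(C)c2nc(Nc3ccc(S(N)(=O)=O)cc3)ncc21`: 136 nM
compound 2 `CCCC1C(=O)N(C)c2cnc(Nc3ccc(S(N)(=O)=O)cc3)nc2N1C`: 206 nM

Among the measured compounds shown here, compound 2 stands at the higher of the two numbers, but the only step that joins it to another compound, a 1.5-fold higher number from compound 1 to compound 2 (0.18 log units; within the scatter), is within the scatter, so the two values cannot be told apart.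

Compound 3 `CC(C)C1C(=O)N(C)c2cnc(Nc3ccc(S(N)(=O)=O)cc3)nc2N1C` is not yet measured. It differs from compound 2 in one place: isopropyl in place of propyl on a saturated ring carbon. For the measured compounds named here, the one step that bears on this change is the exchange at the same saturated ring carbon, a 1.5-fold higher number from compound 1 to compound 2 (0.18 log units; within the scatter), which stayed within the scatter. That step swapped a ring for a chain; the present step keeps a chain and only rearranges it, so it offers no reason to expect a larger move. Compound 3 is therefore expected to sit close to compound 2, with a 1.1-fold lower number from compound 2 to compound 3 (0.06 log units; within the scatter) as the estimated step. The estimate for compound 3 in this assay is 180 nM, with a range from 80 nM to 400 nM.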

Compound 3, half-maximal inhibitory concentration: 254 nM
The estimate for compound 3 lay 1.4-fold (0.15 log units) below the measured number; low and high end bracket the measured number.
By their numbers in this assay, from the lowest: compounds 1, 2 and 3 (each within the scatter of the next).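

With compound 3, the saturated ring carbon has now carried a ring, a straight chain and a branched chain. In this assay, rearranging the chain from propyl to isopropyl stays within the scatter (a 1.2-fold higher number from compound 2 to compound 3 (0.09 log units; within the scatter)), which shows that branching at this carbon produces no readable change in this series. The direct exchange of cyclopropyl for isopropyl also stays within the scatter (a 1.9-fold higher number from compound 1 to compound 3 (0.27 log units; within the scatter)), so the three groups cannot be told apart here, and nothing available offers an explanation for this result.

As far as these compounds go, all three groups at this position are small hydrocarbon groups, so it remains open whether a longer chain, a phenyl ring, an amine or a carboxylic acid on the same carbon would produce a step beyond the scatter. The shared core and its sulfonamide are identical in all three compounds, which leaves open what a change elsewhere in the structure would do.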